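Swapping the Amide Aryl Group: Bromo Out, Methoxy In

The source may hold more compounds than are shown below. What is called first, only, known or untested is meant among the compounds shown, and "the series" means these compounds.

Compound 1, `COc1cc2oc(-c3cccc(NC(=O)c4ccc(Br)cc4)c3)cc(=O)c2c(OC)c1OC`, gives 8850 nM in a functional assay on HepG2 cells (Homo sapiens) for inhibition, read by MTT assay; on this read-out higher numbers stand for weaker inhibition of growth and lower numbers for stronger inhibition of growth.
Compound 2, `COC(=O)c1ccc(C(=O)Nc2cccc(-c3cc(=O)c4c(OC)c(OC)c(OC)cc4o3)c2)cc1`, reaches only a limit of > 100000 nM in this assay.
Compound 3, `COc1cc2oc(-c3cccc(NC(=O)c4ccc(C(F)(F)F)cc4)c3)cc(=O)c2c(OC)c1OC`, gives 61100 nM in this assay.

All three share one core and differ only in the group attached to the amide carbonyl. Compound 1 has the lowest of the two numbers shown; compound 3 stands a 6.9-fold higher number from compound 1 to compound 3 (0.84 log units; beyond the scatter). For compound 2 the assay gave no number but a limit, (the limit of > 100000 nM in this assay, at which 1 of the 3 values shown sits), so the step of an at least 11-fold higher number from compound 1 to compound 2 (1.05 log units; beyond the scatter) is known only as a floor.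

The next compound, compound 4, `COc1cccc(C(=O)Nc2cccc(-c3cc(=O)c4c(OC)c(OC)c(OC)cc4o3)c2)c1`, changes the same group again: 3-methoxyphenyl in place of 4-bromophenyl on a carbonyl carbon. Here the 4-bromophenyl leaves and a 3-methoxyphenyl enters on the carbonyl carbon. Among the compounds with values here, no measured step makes exactly this exchange. The two steps that do touch this position, an at least 11-fold higher number from compound 1 to compound 2 (1.05 log units; beyond the scatter) and a 6.9-fold higher number from compound 1 to compound 3 (0.84 log units; beyond the scatter), both replace bromo with another group and both raise the number, one by a large amount, one by a modest amount. Compound 4 is therefore expected to give a higher number than compound 1, though the size is uncertain. The estimate for compound 4 in this assay is 25000 nM, with a range from 7000 nM to 90000 nM. That estimate means a step of a 2.8-fold higher number from compound 1 to compound 4 (0.45 log units; beyond the scatter).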

Compound 4, concentration for 50% growth inhibition: 7060 nM
The estimate for compound 4 lay 3.5-fold (0.55 log units) above the measured number; low and high end bracket the measured number.
By their numbers in this assay, from the lowest: compounds 4 and 1 (each within the scatter of the next); then compound 3. At a limit, above all of these: compound 2.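

Exchanging 4-bromophenyl for 3-methoxyphenyl on the carbonyl carbon leaves the number in this assay level within the scatter, with a 1.3-fold lower number from compound 1 to compound 4 (0.10 log units; within the scatter). Within the data shown here, the earlier exchanges at this position all raised the number from that of compound 1, so this is the first sign that the low number does not depend on the 4-bromophenyl alone, and the 3-methoxyphenyl stands clearly apart from the other two groups, with an 8.7-fold lower number from compound 3 to compound 4 (0.94 log units; beyond the scatter) and with an at least 14-fold lower number from compound 2 to compound 4 (1.15 log units; beyond the scatter). The second of these steps is only a floor, since compound 2 gave a limit and not a number: the limit of > 100000 nM in this assay, at which 1 of the 4 values shown sits.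

Compound 4 differs from compound 1 both in the group on the ring and in where that group sits, so only a 4-methoxyphenyl or a 3-bromophenyl could show which of the two differences matters. As far as these compounds go, it also remains open how this assay would respond to a plain phenyl with no added group, or to a phenyl carrying an amine or a carboxylic acid.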